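Adding a second ring hydroxy to compound 2

This account rests on a few compounds, and the source may have more. Where it says the series, first, only, none or still open, it means among the compounds named here.

Measured so far:
- compound 1 `COc1cc(/C=N/NC(=O)CCCc2nc3ccccc3c(=O)[nH]2)ccc1O`: 115000000 nM
- compound 2 `O=C(CCCc1nc2ccccc2c(=O)[nH]1)N/N=C/c1ccc(O)cc1`: 170000000 nM

Both values come from a physicochemical assay, read by spectrophotometry, with a stated time of 6 min; on this read-out lower numbers stand for stronger inhibition and higher numbers for weaker inhibition. Compound 2, at 170000000 nM, lies within the scatter of compound 1, so the pair gives no ranking.

Compound 3 `O=C(CCCc1nc2ccccc2c(=O)[nH]1)N/N=C/c1ccc(O)c(O)c1` is unmeasured. It differs from compound 2 by hydroxy in place of hydrogen on an aromatic carbon, 4-hydroxyphenyl to 3,4-dihydroxyphenyl.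

Among the compounds with values here, one measured step bears on this change, at the same place, ortho to a hydroxy group: a 1.5-fold higher number from compound 1 to compound 2 (0.17 log units; within the scatter). That step exchanges methoxy and hydrogen, not hydroxy, so it is only a loose guide. A modest move to a lower number is expected in this assay, with a wide margin that includes no change.

The expected value for compound 3 is 60000000 nM, with an estimated range of 8000000 nM to 170000000 nM. The estimate means an expected 2.8-fold lower number from compound 2 to compound 3 (0.45 log units; beyond the scatter).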

Compound 3, half-maximal inhibitory concentration: 50000000 nM
The estimate for compound 3 lay 1.2-fold (0.08 log units) above the measured number, within the range that was stated.
By their numbers in this assay, from the lowest: compound 3; then compounds 1 and 2 (each within the scatter of the next).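

In this assay, this position now gives a readable change: hydroxy in place of hydrogen on an aromatic carbon, ortho to a hydroxy group, gives a 3.4-fold lower number from compound 2 to compound 3 (0.53 log units; beyond the scatter) and so stronger inhibition, while the earlier exchange of methoxy and hydrogen at the same place stayed within the scatter. Hydrogen in place of methyl on the oxygen gives a 2.3-fold lower number from compound 1 to compound 3 (0.36 log units; beyond the scatter), so the free hydroxy also separates from methoxy, and 3,4-dihydroxyphenyl is the only ring substitution in this set set apart from the other two, though both steps are modest. Nothing available accounts for either step.

On these data alone, whether an amine or a carboxylic acid at this position would behave like hydroxy remains open. Also open, as far as these compounds go, is whether the step holds without the hydroxy group already present in 4-hydroxyphenyl.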